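Ethyl ester in place of the acid on the shared core

The source may report more compounds than this note shows. Statements on the series, on what has been measured and on what is new or still open speak of the compounds shown alone.

Three compounds built on the shared core have been run in a functional assay on the whole organism (blood, strain Charles Foster/Wistar albino) with Rattus norvegicus as the target, with a stated time of 30 min, at a dose of 100 mg/kg by the oral route; on this read-out higher numbers stand for more inhibition at the one dose given (going by the name of the read-out) and lower numbers for less inhibition. Compound 1 `COc1ccc(-c2cc(-c3ccccc3)no2)c(OCC(O)CN2CCCCC2)c1` gives 17%, compound 2 `CCCCN(C)CCCOc1cc(OC)ccc1-c1cc(-c2ccccc2)no1` gives 15%, and compound 3 `COc1ccc(-c2cc(-c3ccccc3)no2)c(OCC(=O)O)c1` gives 11.7%, the lowest of the three numbers, though a number 3.3 percentage points lower from compound 2 to compound 3 (within the scatter) and a number 5.3 percentage points lower from compound 1 to compound 3 (within the scatter) both sit within the scatter. Compound 4 `CCOC(=O)COc1cc(OC)ccc1-c1cc(-c2ccccc2)no1` is compound 3 with ethyl in place of hydrogen on an oxygen next to a carbonyl group. Going by the values given here, no measured step touches that oxygen; the steps that exist, a number 2 percentage points lower from compound 1 to compound 2 (within the scatter) and those to the carboxy compound, all lie within the scatter, so no step beyond the scatter is expected in this assay either. Compound 4 is therefore estimated at 14%, between 5% and 24%, an expected change of a number 2.3 percentage points higher from compound 3 to compound 4 (within the scatter).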

Compound 4, a percentage reported as inhibition, in the whole organism at one dose (the size of the read-out at that dose, not a potency): 10.4%
Compound 4: the middle estimate sits 3.6 percentage points above what was measured, within the range that was stated.
By their numbers in this assay, from the lowest: compounds 4, 3, 2 and 1 (each within the scatter of the next).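

Ethyl on this oxygen, turning the carboxy group into ethoxycarbonyl, gives a number 1.3 percentage points lower from compound 3 to compound 4 (within the scatter) in this assay, so the first change shown at this oxygen leaves the number within the scatter. The ester also stays within the scatter of both amine-bearing compounds, with a number 4.6 percentage points lower from compound 2 to compound 4 (within the scatter) and a number 6.6 percentage points lower from compound 1 to compound 4 (within the scatter), so all four compounds remain indistinguishable on this read-out. Nothing available explains these small differences. The compounds shown leave open whether a longer chain on this oxygen, such as butyl, or an amide made with piperidine in place of the ester would give a step beyond the scatter.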